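This account rests on a few compounds, and the source may have more. Where it says the series, first, only, none or still open, it means among the compounds named here.

Compound 1 `CC(O)(CSc1ccc(C(F)(F)F)cc1)C(=O)Nc1cccc(S(F)(F)(F)(F)F)c1` and compound 2 `CC(O)(CSc1cccc(C(F)(F)F)c1)C(=O)Nc1cccc(S(F)(F)(F)(F)F)c1` are built on one shared core and differ in a single place: 3-(trifluoromethyl)phenyl in place of 4-(trifluoromethyl)phenyl on a sulfur. In a functional assay on LNCaP cells (Homo sapiens) for antiproliferative activity, read by propidium iodide staining, with a stated time of 96 h (on this read-out higher numbers stand for weaker inhibition and lower numbers for stronger inhibition), compound 1 gives 17500 nM, and compound 2 gives 12700 nM, so this change produced a 1.4-fold lower number from compound 1 to compound 2 (0.14 log units; within the scatter).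

Compound 3 `CC(O)(CS(=O)(=O)c1ccc(C(F)(F)F)cc1)C(=O)Nc1ccc(S(F)(F)(F)(F)F)cc1` rests on another core; how that core differs from the core of compound 1 is not broken down here. In this assay compound 3 gives 20700 nM, a number close to those of compound 1 and compound 2.

Compound 4 `CC(O)(CS(=O)(=O)c1cccc(C(F)(F)F)c1)C(=O)Nc1ccc(S(F)(F)(F)(F)F)cc1` has not yet been measured. Its relation to compound 3 mirrors the relation of compound 2 to compound 1: 3-(trifluoromethyl)phenyl in place of 4-(trifluoromethyl)phenyl on a sulfonyl sulfur. Among the measured compounds shown here, this is the same kind of change as the one from compound 1 to compound 2, not the same change, for the surroundings differ. In compound 1 the group sits on a sulfur whose other neighbours are a saturated chain carbon, whereas in compound 3 it sits on a sulfonyl sulfur whose other neighbours are a saturated chain carbon.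

For the measured compounds named here, since the only earlier instance gave a 1.4-fold lower number from compound 1 to compound 2 (0.14 log units; within the scatter), the step from compound 3 to compound 4 in this assay is expected to be a 1.4-fold lower number from compound 3 to compound 4 (0.14 log units; within the scatter). That expectation rests on a single example and on a change that stayed within the scatter. Compound 4 is therefore estimated to give 15000 nM, most likely between 7500 nM and 30000 nM.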

Compound 4, half-maximal inhibitory concentration: 21000 nM
Compound 4: the middle estimate sits 1.4-fold (0.15 log units) below what was measured; the measured number falls inside the stated range.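

In this assay, putting 3-(trifluoromethyl)phenyl in place of 4-(trifluoromethyl)phenyl on the sulfonyl sulfur gave a 1.0-fold higher number from compound 3 to compound 4 (0.01 log units; within the scatter), so this step cannot be told apart from no change at all. Set beside the same kind of change on the core of compound 1, the two results agree as closely as such measurements allow: the same change on two cores in this assay, a 1.4-fold lower number (0.14 log units; within the scatter) from compound 1 to compound 2 and a 1.0-fold higher number (0.01 log units; within the scatter) from compound 3 to compound 4, 1.4-fold (0.15 log units) apart, within the scatter of two such steps. This shows that the change did not produce a step beyond the scatter on either of these two cores, but it does not show that the change has a real effect that carries from one core to the other, since neither step stands clear of the scatter, and two cores are too few to support a rule for the series.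

The compounds shown leave open whether a change on this aromatic ring can move the number beyond the scatter at all, for instance with a nitrile or a chlorine atom in place of the trifluoromethyl group. They also leave open what would happen with a different link to the ring, such as an amine in place of the sulfur or sulfonyl group.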